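Shortening the Long Acyl Chain of Compound 1

The source may report more compounds than this note shows. Statements on the series, on what has been measured and on what is new or still open speak of the compounds shown alone.

Measured so far:
compound 1 `CCCCCCCCCCCCCCCCCCCCCCCC(=O)NCCCC[C@H](NC(=O)[C@H](C)NC)C(=O)N1CCC[C@H]1C(=O)NC(c1ccccc1)c1ccccc1` — > 100000 nM
compound 2 `CN[C@@H](C)C(=O)N[C@@H](CCCCNC(=O)Nc1ccc(Oc2ccc(NC(=O)NCCCC[C@H](NC(=O)[C@H](C)NC)C(=O)N3CCC[C@H]3C(=O)NC(c3ccccc3)c3ccccc3)cc2)cc1)C(=O)N1CCC[C@H]1C(=O)NC(c1ccccc1)c1ccccc1` — 14400 nM
compound 3 `CN[C@@H](C)C(=O)N[C@@H](CSCCS(=O)(=O)CCSC[C@H](NC(=O)[C@H](C)NC)C(=O)N1CCC[C@H]1C(=O)NC(c1ccccc1)c1ccccc1)C(=O)N1CCC[C@H]1C(=O)NC(c1ccccc1)c1ccccc1` — 52400 nM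

All three were tested in a functional assay on MDA-MB-231 cells (Homo sapiens) for inhibition, with a stated time of 48 h; a lower number here means that less compound is needed, a higher number that more compound is needed for the effect. Going by the values given here, for compound 1 the entry > 100000 nM is a limit of the assay, not a measured number; it is the one value that sits at the limit of > 100000 nM in this assay, at which 1 of the 3 values shown sits. Compound 2 gives 14400 nM and compound 3 gives 52400 nM, both measured numbers. Compound 4 `CCCCCCCCCCCCCCCC(=O)NCCCC[C@H](NC(=O)[C@H](C)NC)C(=O)N1CCC[C@H]1C(=O)NC(c1ccccc1)c1ccccc1` differs from compound 1 by hydrogen in place of octyl on a saturated chain carbon, ten or more bonds along the chain from a carbonyl carbon. Among the compounds with values here, with no measured step of this kind to lean on, the expected step in this assay from compound 1 to compound 4 is a number no higher from compound 1 to compound 4 (the limit leaves the size open), nothing beyond the scatter. Compound 4 is therefore estimated at 100000 nM, with a range from 30000 nM to 300000 nM, most likely again reported only as a limit.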

Compound 4, half-maximal effective concentration: 6100 nM
Compound 4: middle estimate off by 16-fold (1.21 log units), on the high side; the measured number lies below the stated range.
By their numbers in this assay, from the lowest: compound 4; then compound 2; then compound 3. At a limit, above all of these: compound 1.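

Putting hydrogen in place of octyl on a saturated chain carbon, ten or more bonds along the chain from a carbonyl carbon, gives an at least 16-fold lower number from compound 1 to compound 4 (1.21 log units; beyond the scatter) in this assay. Going by these compounds alone, this is the first step read at this position, and it shows that the outer part of the acyl chain, far from the shared core, still affects the result. Compound 1 is only a limit, so the full size of the step is unknown: the limit of > 100000 nM in this assay, at which 1 of the 4 values shown sits.

A still shorter chain might lower the number further or raise it again. Going by these compounds, what an amine or a carboxylic acid in place of octyl would do also stays open.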